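A few compounds are considered here, and "the series" means these few. Any claim that something is new, unique, unknown or untested is made for them only; others in the source may bear on it.

Compound 1, `C=CCN(Cc1cccs1)C(=O)COc1ccc(C)cc1`, is the point of departure. In an assay on HEK293 cells for agonist activity at transient receptor potential cation channel subfamily M member 8 (Homo sapiens), read by fluorescence and calcium flux, with a stated time of 15 min (on this read-out lower numbers stand for an effect already at smaller amounts and higher numbers for an effect only at larger amounts of compound), compound 1 gives 20 nM, the lowest of the three numbers recorded so far. Compound 2, `CCN(Cc1ccccc1)C(=O)COc1ccc(C)cc1`, gives 1880 nM in this assay, and compound 3, `CCN(Cc1cccs1)C(=O)CCc1ccc(C)cc1`, gives 93 nM; both of these differ from compound 1 in more than one place, so neither pair tells anything about a single alteration, and the numbers are simply set beside one another.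

The step to compound 4, `Cc1ccc(OCC(=O)N(Cc2cccs2)C(C)C)cc1`, changes one thing: isopropyl in place of allyl on an amide-type nitrogen. Going by the values given here, no measured pair in the set isolates a change at this amide-type nitrogen, so the direction has to be guessed from the structural change alone. Since the group that leaves and the group that enters are matched in size, with the double bond of the allyl as the only difference, a step of modest size is expected, most likely toward a somewhat higher number, though staying within the scatter is also quite possible. The account therefore expects a step of a 3.0-fold higher number from compound 1 to compound 4 (0.48 log units; beyond the scatter) in this assay. For compound 4 the estimate in this assay is 60 nM, with a range from 15 nM to 250 nM.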

Compound 4, half-maximal effective concentration: 70 nM
Estimate against measurement, compound 4: 1.2-fold (0.07 log units) below; the measured number falls inside the stated range.
By their numbers in this assay, from the lowest: compound 1; then compounds 4 and 3 (each within the scatter of the next); then compound 2.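

Going by these compounds alone, replacing allyl with isopropyl on the amide-type nitrogen gives the first comparison in the set that can be read at a single place: in this assay it produces a 3.5-fold higher number from compound 1 to compound 4 (0.54 log units; beyond the scatter) as a modest step. The two groups match in their count of heavy atoms, all carbon, and neither has a ring, a hydrogen-bond donor or acceptor, or a net charge, so the double bond outside aromatic rings is the one counted feature that leaves. The result thus shows that the read-out at this position responds to an exchange that keeps those counts unchanged, but nothing available here bears on why the number moves.

The compounds shown leave open whether the double bond itself or the shape of the chain carries this step, and a straight propyl chain on the same nitrogen would bear on that question. They also leave open how a longer chain, a cyclopropyl ring or a chain ending in an amine would fare at this position on the core of compound 1 .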